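From phenyl to 3,5-dibromophenyl in compound 4

The compounds below may be only part of what the source reports. "The series", "measured", "known", "first", "only" and "open" are said of these compounds alone.

Measured so far in a functional assay on HT-29 cells (Homo sapiens) for antiproliferative activity, read by sulforhodamine B assay, with a stated time of 48 h (on this read-out higher numbers stand for weaker inhibition and lower numbers for stronger inhibition), for three compounds:
Compound 1 `CCCN1CCN(c2ccc(S(=O)(=O)Oc3cc(Cl)c(Cl)cc3Cl)cc2)C1=O` gives 19000 nM
Compound 2 `CCCN1CCN(c2ccc(S(=O)(=O)Oc3ccc(C)cc3)cc2)C1=O` gives 25000 nM
Compound 3 `CCCCN1CCN(c2ccc(S(=O)(=O)Oc3ccccc3)cc2)C1=O` gives > 100000 nM

Compound 3 stands at > 100000 nM in this assay and that entry is a limit of the assay, not a number. Compound 4 `CCCCN1CCN(c2ccc(S(=O)(=O)Oc3cc(Br)cc(Br)c3)cc2)C1=O` keeps the butyl chain and the shared core of compound 3. The change is 3,5-dibromophenyl in place of phenyl on an oxygen and in words it puts 3,5-dibromophenyl in place of phenyl on an oxygen.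

Among the measured compounds shown here, the one measured step that bears on this is a 1.3-fold higher number from compound 1 to compound 2 (0.12 log units; within the scatter) and it exchanges one substituted ring on that oxygen for another. For the measured compounds named here, compound 1 and compound 2 carry a propyl chain, however, and no measured step isolates the effect of the chain or compares a substituted ring with plain phenyl. Even so, compound 2 gives 25000 nM with a substituted ring, so compound 4 is expected to inhibit more strongly than compound 3. The expected size is an at least 5.0-fold lower number from compound 3 to compound 4 (0.69 log units; beyond the scatter) and this remains an estimate. The estimated value for compound 4 is 20000 nM (expected range 6000 nM to 70000 nM).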

Compound 4, half-maximal inhibitory concentration: 43000 nM
Compound 4: the middle estimate sits 2.2-fold (0.33 log units) below what was measured; low and high end bracket the measured number.
By their numbers in this assay, from the lowest: compounds 1, 2 and 4 (each within the scatter of the next, the first and the last beyond it). At a limit, above all of these: compound 3.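

In this assay, among the compounds shown here, 3,5-dibromophenyl in place of phenyl on an oxygen gives an at least 2.3-fold lower number from compound 3 to compound 4 (0.36 log units; beyond the scatter), the first measured comparison of a substituted ring with plain phenyl at this position, made with the butyl chain and the shared core held constant. The earlier step between two substituted rings, a 1.3-fold higher number from compound 1 to compound 2 (0.12 log units; within the scatter), showed no separation, whereas this change moves the result beyond the scatter, so the presence of the two bromines on the ring is linked to stronger inhibition in this pair. The entry for compound 3 is a limit of the assay and not a number, so only a lower bound on the size of this step can be read: the limit of > 100000 nM in this assay, at which 1 of the 4 values shown sits.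

The compounds shown leave open whether a ring with a single bromine, or one carrying chlorine or methyl in place of the bromines, would give the same step on the butyl series. They also leave open how the butyl and propyl chains compare on an identical ring, and whether a longer chain such as hexyl or an amine on that chain would change the result.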